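The compounds below may be only part of what the source reports. "The series", "measured", "known", "first", "only" and "open" are said of these compounds alone.

Measured so far:
Compound 1, `CC/C(=C(/c1ccc(/C=C/C(=O)O)cc1)c1cc2ccccc2[nH]1)c1ccccc1`: in a functional assay on MCF7 cells (Homo sapiens) for inhibition (a lower number here means a stronger inhibitor, a higher number a weaker inhibitor), compound 1 gives 108 nM.
Compound 2, `CC/C(=C(/c1ccc(/C=C/C(=O)O)cc1)c1cc2ccccc2[nH]1)c1ccccc1Cl`: in this assay compound 2 gives 42 nM.
Compound 3, `CC/C(=C(/c1ccc(/C=C/C(=O)O)cc1)c1cc2ccccc2[nH]1)c1ccccc1OC(F)(F)F`: in this assay compound 3 gives 206 nM.

Among these three, compound 3 has the highest number. Its nearest neighbour is compound 1, and that gap, a 1.9-fold higher number from compound 1 to compound 3 (0.28 log units; within the scatter), lies within the scatter, so the two cannot be ordered. The gap to compound 2, a 4.9-fold higher number from compound 2 to compound 3 (0.69 log units; beyond the scatter), is beyond the scatter.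

Compound 4, `CC/C(=C(/c1ccc(/C=C/C(=O)O)cc1)c1cc2ccccc2[nH]1)c1cccc(C)c1`, shares the core of compound 3; the change is 3-methylphenyl in place of 2-(trifluoromethoxy)phenyl on a double-bonded chain carbon bound to a double-bonded chain carbon and a saturated chain carbon. Among the measured compounds shown here, no measured step bears on a methyl group, so the nearest guide is the removal of the trifluoromethoxy group, a 1.9-fold higher number from compound 1 to compound 3 (0.28 log units; within the scatter), which gave a change within the scatter, and the chloro comparison, a 2.6-fold lower number from compound 1 to compound 2 (0.41 log units; beyond the scatter), where a small group on that ring gave a modestly lower number. A modestly lower number than compound 3 is therefore expected, though the methyl sits at a place untested here. The expected step is a 2.1-fold lower number from compound 3 to compound 4 (0.31 log units; beyond the scatter). For compound 4 the estimate in this assay is 100 nM, with a range from 40 nM to 260 nM.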

Compound 4, half-maximal inhibitory concentration: 140 nM
Compound 4: the middle estimate sits 1.4-fold (0.15 log units) below what was measured; the measured number falls inside the stated range.
By their numbers in this assay, from the lowest: compound 2; then compounds 1, 4 and 3 (each within the scatter of the next).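

Putting a methyl on the phenyl ring, as 3-methylphenyl, gives a step within the scatter in this assay (a 1.3-fold higher number from compound 1 to compound 4 (0.11 log units; within the scatter)), and exchanging 2-(trifluoromethoxy)phenyl for 3-methylphenyl does the same (a 1.5-fold lower number from compound 3 to compound 4 (0.17 log units; within the scatter)). So the unsubstituted phenyl, 3-methylphenyl and 2-(trifluoromethoxy)phenyl cannot be ordered at this position, while 2-chlorophenyl remains apart from all three, including 3-methylphenyl (a 3.3-fold higher number from compound 2 to compound 4 (0.52 log units; beyond the scatter)), and compound 2 is the strongest inhibitor of the four. This makes compound 2 the single clear departure in the set, and no measurement at hand accounts for it.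

Because 2-chlorophenyl and 3-methylphenyl differ in both the group and where it sits on the ring, these compounds cannot separate the effect of chloro in place of methyl from the effect of its location, and a methyl in the place held by chloro, or a chloro in the place held by methyl, would be needed to do so. As far as these compounds go, it also remains open whether the lower number is particular to chloro or would extend to other small groups on this ring, such as a fluoro or a methoxy group.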